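Methoxymethyl in place of bromo: working notes

A few compounds are considered here, and "the series" means these few. Any claim that something is new, unique, unknown or untested is made for them only; others in the source may bear on it.

In a functional assay on MES-SA cells (Homo sapiens) for inhibition, with a stated time of 72 h, in the presence of a further agent that is not named here (a lower number here means a stronger inhibitor, a higher number a weaker inhibitor), compound 1 (`Oc1c(CN2CCCC2)ccc2cccnc12`) gives 3980 nM; 3980 nM (2 entries). In this assay, among the compounds with values here, compound 2 (`Oc1c(CN2CCCC2)cc(Br)c2cccnc12`) gives 4470 nM, its only single number, and one further entry for it carries no single number. These two values lie within the usual scatter of each other, so no order can be drawn between them. Compound 3 (`COCc1cc(CN2CCCC2)c(O)c2ncccc12`) has not yet been measured in this assay. It has methoxymethyl in place of bromo on an aromatic carbon, para to a hydroxy group (methoxymethyl in place of bromo on an aromatic carbon). Within the data shown here, no measured step speaks directly to this exchange. No change beyond the scatter is expected and no direction is favoured, so the expected step is a 1.1-fold lower number from compound 2 to compound 3 (0.05 log units; within the scatter). For compound 3 the estimated value is 4000 nM, with an expected range of 1500 nM to 10000 nM.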

Compound 3, half-maximal inhibitory concentration: 10500 nM
For compound 3 the middle estimate is 2.6-fold (0.42 log units) below the measured one; measured number above the stated range.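

In this assay, within the data shown here, this position, para to a hydroxy group, proves not to be indifferent to its substituent: methoxymethyl in place of bromo gives the only step that lies beyond the scatter (a 2.3-fold higher number from compound 2 to compound 3 (0.37 log units; beyond the scatter)). The values of compound 1 and compound 2 showed no order, so that pair gave no sign that a change here could move the number. The step is modest and points towards weaker inhibition, and nothing at hand bears on why.

Among these compounds, the single exchange does not separate the ether oxygen of methoxymethyl from its chain length, since both enter together. An ethyl group, a hydroxymethyl group or an aminomethyl group at this carbon would show whether the oxygen, the chain or neither governs the shift.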